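Methoxy added to the aminoethylamino quinolone core

A few compounds are considered here, and "the series" means these few. Any claim that something is new, unique, unknown or untested is made for them only; others in the source may bear on it.

Compound 1 `COc1c(N2CC[C@@H](CN)C2)c(F)cc2c(=O)c(C(=O)O)cn(Cc3ccc(-c4ccccc4)cc3)c12`: 26000 nM
Compound 2 `CNCCNc1cc2c(cc1F)c(=O)c(C(=O)O)cn2Cc1ccc(-c2ccccc2)cc1`: > 200000 nM
Compound 3 `NCCNc1cc2c(cc1F)c(=O)c(C(=O)O)cn2Cc1ccc(-c2ccccc2)cc1`: 72800 nM

In an assay on isolated protein for inhibition of DNA topoisomerase 1 (Homo sapiens), with a stated time of 15 min (on this read-out higher numbers stand for weaker inhibition and lower numbers for stronger inhibition), compound 3 gives 72800 nM, the highest of the two numbers shown; compound 1 gives 26000 nM. For compound 2 only a limit is reported, > 200000 nM, the limit at which one of the three values sits (the limit of > 200000 nM in this assay, at which 1 of the 3 values shown sits). For the measured compounds named here, the single measured step, an at least 2.7-fold lower number from compound 2 to compound 3 (0.43 log units; beyond the scatter), concerns the amine and not the aromatic ring.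

Compound 4 `COc1c(NCCN)c(F)cc2c(=O)c(C(=O)O)cn(Cc3ccc(-c4ccccc4)cc3)c12` differs from compound 3 by methoxy in place of hydrogen on an aromatic carbon. Going by the values given here, no measured step bears directly on this change: compound 1 carries the same methoxy group but a different amine, so its number and that of compound 3 cannot be separated into two steps. With compound 1 at 26000 nM beside compound 3, a modest step toward a lower number is expected in this assay, a 1.8-fold lower number from compound 3 to compound 4 (0.26 log units; within the scatter), though a number within the scatter of compound 3 would not surprise. Compound 4 is therefore estimated at 40000 nM, with a range from 15000 nM to 150000 nM.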

Compound 4, half-maximal inhibitory concentration: > 200000 nM
Compound 4: no number, only a limit; the forecaster's own chance of this, stated with the estimate: 10%; middle value at least 5.0-fold (0.69 log units) away from the limit.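

In this assay, for the compounds shown here, methoxy in place of hydrogen on this aromatic carbon, ortho to a (2-aminoethyl)amino group, gives an at least 2.7-fold higher number from compound 3 to compound 4 (0.43 log units; beyond the scatter), the first direct reading of this change, and it points toward weaker inhibition. With the methoxy kept, the amine also matters, as (2-aminoethyl)amino in place of 3-(aminomethyl)pyrrolidin-1-yl gives an at least 7.6-fold higher number from compound 1 to compound 4 (0.88 log units; beyond the scatter). Both steps rest on a limit for compound 4 and not on a number, so their full size stays unknown: the limit of > 200000 nM in this assay, at which 2 of the 4 values shown sit.

The compounds shown leave open whether removing the methoxy from compound 1 would shift its number in the same direction, so the effect of this group with the 3-(aminomethyl)pyrrolidin-1-yl amine remains unknown. They also leave open how a hydroxyl, an ethoxy or a chlorine on this carbon would compare.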